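Swapping a fluorinated phenyl for naphthyl on a silent series

The source may report more compounds than this note shows. Statements on the series, on what has been measured and on what is new or still open speak of the compounds shown alone.

Compound 1 `CCOC(=O)C1=Cc2ccccc2OC1(OCc1cc(-c2ccc(F)cc2F)no1)C(F)(F)F` gives, in a functional assay on MCF7 cells (Homo sapiens) for inhibition, read by MTT assay, with a stated time of 24 h (a lower number here means a stronger inhibitor, a higher number a weaker inhibitor), > 150000 nM, a limit of the assay.
Compound 2 `CCOC(=O)C1=Cc2ccccc2OC1(OCc1cn(CC(=O)Nc2ccc(C)cc2)nn1)C(F)(F)F` gives, in this assay, > 150000 nM, a limit of the assay.
Compound 3 `CCCCCCCCn1cc(COC2(C(F)(F)F)Oc3ccccc3C=C2C(=O)OCC)nn1` gives, in this assay, > 150000 nM, a limit of the assay.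

Compound 1 stands nowhere on a scale of numbers: it sits at the limit of > 150000 nM in this assay, at which 3 of the 3 values shown sit. Among the compounds with values here, the only pair that differs in one place, compound 2 and compound 3, gives a step that the two limits leave unreadable from compound 2 to compound 3, so no step of any size can be read from the measured compounds, and no change yet shows any effect beyond the scatter.

Compound 4 `CCOC(=O)C1=Cc2ccccc2OC1(OCc1cc(-c2ccc3ccccc3c2)no1)C(F)(F)F` shares the core of compound 1 and differs from it in one place: naphthalen-2-yl in place of 2,4-difluorophenyl on an aromatic carbon. Within the data shown here, none of the measured steps bears on this change, since none is readable. With every measured compound at a limit and no readable step in hand, compound 4 is expected to give 150000 nM, with a range from 50000 nM to 500000 nM, most likely again only as a limit. The step this estimate means, a number no higher from compound 1 to compound 4 (the limit leaves the size open), is expected to be none beyond the scatter.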

Compound 4, half-maximal inhibitory concentration: 65400 nM
Compound 4: middle estimate off by 2.3-fold (0.36 log units), on the high side; measured number inside the range.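

In this assay, within the data shown here, naphthalen-2-yl in place of 2,4-difluorophenyl gives the first readable number in this set, with an at least 2.2-fold lower number from compound 1 to compound 4 (0.36 log units; beyond the scatter). Among these compounds, the group on this aromatic carbon, next to the ring nitrogen, can therefore move the result beyond the usual scatter, which the earlier compounds could not show, as the step between compound 2 and compound 3 cannot be read. On these data alone, the full size of the new step stays open, because compound 1 stands at a limit: the limit of > 150000 nM in this assay, at which 3 of the 4 values shown sit.

The change adds a second aromatic ring and removes both fluorines at once, so the compounds shown do not tell which of the two matters. A plain phenyl group or a naphthalen-1-yl group at this place would help to separate these two parts of the change.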